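The source may hold more compounds than are shown below. What is called first, only, known or untested is meant among the compounds shown, and "the series" means these compounds.

Compound 1 `Cc1cc(C)c(Oc2cc(NCCn3ccc(=O)[nH]c3=O)nc(Cl)n2)c(C)c1` and compound 3 `Cc1cc(C)c(Oc2nc(NCCn3ccc(=O)[nH]c3=O)ncc2Cl)c(C)c1` are built from the same atoms joined differently; the difference between the two cores is not broken down here. In an ADME assay on MT4 cells (Homo sapiens) for cytotoxicity, read by MTT assay, with a stated time of 5 days (on this read-out lower numbers stand for higher toxicity in this test and higher numbers for lower toxicity in this test), compound 1 gives 76400 nM, while compound 3 gives 2490 nM. Compound 2 `Cc1cc(C#N)cc(C)c1Oc1nc(NCCn2ccc(=O)[nH]c2=O)ncc1Cl` carries, relative to compound 3, a cyano in place of methyl on an aromatic carbon. In this assay compound 2 reaches only a limit, > 11600 nM. The size of an at least 4.6-fold higher number from compound 3 to compound 2 (0.66 log units; beyond the scatter) is therefore bounded only from below because of the limit of > 11600 nM in this assay, at which 1 of the 3 values shown sits. Compound 4 `Cc1cc(C#N)cc(C)c1Oc1cc(NCCn2ccc(=O)[nH]c2=O)nc(Cl)n1` carries the same change made on compound 1 (cyano in place of methyl on an aromatic carbon). Compound 4 is expected to shift by a 1.4-fold higher number from compound 1 to compound 4 (0.16 log units; within the scatter), an expectation resting on compound 1 at 76400 nM and on the direction of an at least 4.6-fold higher number from compound 3 to compound 2 (0.66 log units; beyond the scatter). The estimate for compound 4 in this assay is 110000 nM, expected to lie between 40000 nM and 300000 nM.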

Compound 4, half-maximal cytotoxic concentration: 27900 nM
The estimate for compound 4 lay 3.9-fold (0.60 log units) above the measured number; measured number below the stated range.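

In this assay, cyano in place of methyl on an aromatic carbon gives a 2.7-fold lower number from compound 1 to compound 4 (0.44 log units; beyond the scatter). Set beside the same change on the other core, this step shows that neither its direction nor its size carries over from one core to the other: the same change on two cores in this assay, an at least 4.6-fold higher number (0.66 log units; beyond the scatter) from compound 3 to compound 2 and a 2.7-fold lower number (0.44 log units; beyond the scatter) from compound 1 to compound 4, at least 12-fold (1.10 log units) apart, beyond the scatter of two such steps. This comparison rests on two cores only, and the value of compound 2, > 11600 nM, is a limit and not a number, so it shows neither the full size of the gap nor why the two steps part.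

The compounds shown leave open how the change would run on any further core. They also leave open whether a carboxylic acid or an amine on that aromatic carbon, or a longer chain, would follow the cyano on either core.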